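Pyridin-2-yl Gives Way to 1,3-Thiazol-2-yl

The compounds below may be only part of what the source reports. "The series", "measured", "known", "first", "only" and "open" are said of these compounds alone.

Compound 1 `OC[C@H]1OC(n2cnc3c(-c4ccccn4)ncnc32)[C@H](O)[C@@H]1O` was examined in a functional assay on CCRF-CEM cells (Homo sapiens) for inhibition (a higher number here means a weaker inhibitor, a lower number a stronger inhibitor), where compound 1 gives 900 nM. Among the compounds with values here, the only other measured compound, compound 2 `OC[C@H]1OC(n2cnc3c(-c4ccc(F)cc4)ncnc32)[C@H](O)[C@@H]1O`, gives 700 nM in this assay. Compound 1 therefore holds the higher of the two numbers, yet the step of a 1.3-fold lower number from compound 1 to compound 2 (0.11 log units; within the scatter) does not separate the pair beyond the scatter, so neither can be called the stronger inhibitor.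

The unmeasured compound 3 `OC[C@H]1OC(n2cnc3c(-c4nccs4)ncnc32)[C@H](O)[C@@H]1O` differs from compound 1 in one place: 1,3-thiazol-2-yl in place of pyridin-2-yl on an aromatic carbon. A single measured step bears on this change, namely the exchange of the aromatic group at the same position that gave a 1.3-fold lower number from compound 1 to compound 2 (0.11 log units; within the scatter), a result that stayed within the scatter. With nothing else to draw on, the exchange for 1,3-thiazol-2-yl is expected to behave likewise: a step of no more than the scatter, in no particular direction. Compound 3 is accordingly estimated at 800 nM, with a range from 300 nM to 2400 nM, which corresponds to an expected step of a 1.1-fold lower number from compound 1 to compound 3 (0.05 log units; within the scatter).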

Compound 3, half-maximal inhibitory concentration: 2730 nM
Compound 3: the middle estimate sits 3.4-fold (0.53 log units) below what was measured; measured number above the stated range.
By their numbers in this assay, from the lowest: compounds 2 and 1 (each within the scatter of the next); then compound 3.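

In this assay this position proves not to be indifferent to the aromatic group it carries: 1,3-thiazol-2-yl in place of pyridin-2-yl gives a 3.0-fold higher number from compound 1 to compound 3 (0.48 log units; beyond the scatter) and so moves the number beyond the scatter, which the exchange between compound 1 and compound 2 did not do. The comparison with the 4-fluorophenyl group points the same way, with a 3.9-fold higher number from compound 2 to compound 3 (0.59 log units; beyond the scatter) as a second modest step, so that compound 3, with its five-membered aromatic ring, is the weakest inhibitor of the three, while the two six-membered aromatic groups stay within the scatter of each other. Nothing available gives a reason for this difference.

The compounds shown leave open whether the step belongs to the five-membered ring as such or to its sulfur, a question that an oxazol-2-yl or a thiophen-2-yl group at the same carbon would address. They also leave open how this position would respond to a group that is not an aromatic ring at all, such as an amine or a short alkyl chain.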